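Ethynyl in Place of Thiophene: an Expected Gain

The compounds below may be only part of what the source reports. "The series", "measured", "known", "first", "only" and "open" are said of these compounds alone.

Two measured compounds frame the comparison. Compound 1 `C#Cc1cn([C@@H]2O[C@H](CO)[C@@H](O)[C@H]2O)c2ncnc(C)c12` gives 110 nM in a functional assay on K562 cells (Homo sapiens), read by MTT assay, with a stated time of 72 h; on this read-out lower numbers stand for stronger inhibition and higher numbers for weaker inhibition. Compound 2 `COc1ncnc2c1c(-c1cccs1)cn2[C@@H]1O[C@H](CO)[C@@H](O)[C@H]1O` gives 6200 nM in this assay, the highest of the two numbers and beyond the scatter from compound 1. Compound 3 `C#Cc1cn([C@@H]2O[C@H](CO)[C@@H](O)[C@H]2O)c2ncnc(OC)c12` differs from compound 2 by ethynyl in place of thiophen-2-yl on an aromatic carbon. For the measured compounds named here, no step between measured compounds is known for this change. Compound 1 carries the same ethynyl group and gives 110 nM in this assay. On that basis a large downward step is expected a 21-fold lower number from compound 2 to compound 3 (1.32 log units; beyond the scatter). Compound 3 is therefore estimated at 300 nM, within a range from 80 nM to 1500 nM.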

Compound 3, half-maximal inhibitory concentration: 380 nM
Compound 3: the middle estimate sits 1.3-fold (0.10 log units) below what was measured; measured number inside the range.
By their numbers in this assay, from the lowest: compound 1; then compound 3; then compound 2.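

With the ethynyl group in place of thiophen-2-yl, on the aromatic carbon two ring bonds from the ring nitrogen, the result shows a 16-fold lower number from compound 2 to compound 3 (1.21 log units; beyond the scatter) as a direct step, with the methoxy group held constant. Methoxy in place of methyl, with ethynyl held constant, gives a 3.5-fold higher number from compound 1 to compound 3 (0.54 log units; beyond the scatter) and so shows that this second change also moves the number, though only modestly. No measurement shown gives a cause for either step. Going by these compounds, whether a nitrile or a longer alkyne chain at the ethynyl position would give a similar number stays open. So does the effect of an amine in place of methoxy.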